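Replacing 3-Chlorophenyl with 2-Bromophenyl: What to Expect

The source may hold more compounds than are shown below. What is called first, only, known or untested is meant among the compounds shown, and "the series" means these compounds.

Of the compounds shown here, three with a shared core have been tested in a functional assay on MIA PaCa-2 cells (Homo sapiens) for inhibition, read by MTT assay, with a stated time of 48 h, tested at 10 uM; a lower number here means less inhibition of growth, a higher number more inhibition of growth at the concentration tested. Compound 1 (`Cc1oc2c([C@H]3CCN(C)C[C@H]3O)c(O)cc(O)c2c(=O)c1C(O)c1ccc([N+](=O)[O-])cc1`) gives 2%, compound 2 (`Cc1oc2c([C@H]3CCN(C)C[C@H]3O)c(O)cc(O)c2c(=O)c1C(O)c1ccc(Cl)cc1`) gives 15%, and compound 3 (`Cc1oc2c([C@H]3CCN(C)C[C@H]3O)c(O)cc(O)c2c(=O)c1C(O)c1cccc(Cl)c1`) gives 2%. Compound 3 thus stands level with compound 1, and both sit under compound 2.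

The next compound to be tested is compound 4 (`Cc1oc2c([C@H]3CCN(C)C[C@H]3O)c(O)cc(O)c2c(=O)c1C(O)c1ccccc1Br`), which differs from compound 3 as follows: 2-bromophenyl in place of 3-chlorophenyl on a saturated chain carbon bound to an aromatic carbon and an oxygen on a saturated carbon. It has 2-bromophenyl in place of 3-chlorophenyl on a saturated chain carbon bound to an aromatic carbon and an oxygen on a saturated carbon.

Changes at this same place gave a number 13 percentage points lower from compound 2 to compound 3 (beyond the scatter) and no change at the digits printed from compound 1 to compound 3 (within the scatter), while chloro in place of nitro gave a number 13 percentage points higher from compound 1 to compound 2 (beyond the scatter). Among the measured compounds shown here, no tested compound carries 2-bromophenyl, so the expectation rests only on these modest step sizes. The expected change is small and upward, a number 5 percentage points higher from compound 3 to compound 4 (within the scatter). For compound 4 the estimated value is 7%, with an expected range from 0% to 22%.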

Compound 4, percent growth inhibition at one concentration: 10%
Estimate against measurement, compound 4: 3 percentage points below; the range from low to high includes it.
By their numbers in this assay, from the lowest: compounds 1, 3, 4 and 2 (each within the scatter of the next, the first and the last beyond it).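

At this position, a ring carrying bromine gives readings that cannot be separated from any of the earlier groups: the change gives a number 8 percentage points higher from compound 3 to compound 4 (within the scatter), while the other comparisons give a number 8 percentage points higher from compound 1 to compound 4 (within the scatter) and a number 5 percentage points lower from compound 2 to compound 4 (within the scatter). Compound 2 stands apart from compound 1 and compound 3, but compound 4 does not stand apart from any of them, so it falls on neither side of that gap. No measurement shown here explains these readings.

This change swaps the halogen and its place on the ring in one step, leaving their separate contributions unresolved; 2-chlorophenyl or 3-bromophenyl would divide them. On these data alone, how a phenyl ring without a substituent, or one carrying an amine or a carboxylic acid, would read at this position also remains open.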